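This account rests on a few compounds, and the source may have more. Where it says the series, first, only, none or still open, it means among the compounds named here.

Measured so far in a functional assay on HT-29 cells (Homo sapiens) for inhibition, read by luminescence and CellTiter-Glo, with a stated time of 24 h; on this read-out lower numbers stand for an effect already at smaller amounts and higher numbers for an effect only at larger amounts of compound:
- compound 1 `CC(C)Cn1nc(C(=O)N[C@H]2COc3ccccc3N(C)C2=S)nc1Cc1ccccc1`: 1230 nM
- compound 2 `CN1C(=S)[C@@H](NC(=O)c2nc(Cc3ccccc3)n(CCCCCC#N)n2)COc2ccccc21`: 3830 nM

Of these two, compound 2 holds the higher number, 3830 nM. Compound 3 `CN1C(=S)[C@@H](NC(=O)c2nc(Cc3ccccc3)n(C3CCCC3)n2)COc2ccccc21` keeps the shared core and carries cyclopentyl in place of 5-cyanopentyl on an aromatic nitrogen.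

Within the data shown here, only one measured step bears on this substituent, the modest 3.1-fold higher number from compound 1 to compound 2 (0.49 log units; beyond the scatter). That step introduced the nitrile-bearing chain, and compound 3 lacks the nitrile, as compound 1 does. A ring at this nitrogen has not yet been measured, so the comparison is loose. A modest step to a lower number is therefore expected in this assay, similar in size to the measured one. The estimated change is a 2.4-fold lower number from compound 2 to compound 3 (0.38 log units; beyond the scatter). For compound 3 the expected value is 1600 nM, with an estimated range of 600 nM to 4000 nM.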

Compound 3, half-maximal effective concentration: 3530 nM
The estimate for compound 3 lay 2.2-fold (0.34 log units) below the measured number; low and high end bracket the measured number.
By their numbers in this assay, from the lowest: compound 1; then compounds 3 and 2 (each within the scatter of the next).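

In this assay, cyclopentyl in place of 5-cyanopentyl on the aromatic nitrogen gives a 1.1-fold lower number from compound 2 to compound 3 (0.04 log units; within the scatter), so this change does not separate the two groups, and a group without the nitrile does not by that fact alone reach the number of compound 1. Cyclopentyl in place of isobutyl gives a 2.9-fold higher number from compound 1 to compound 3 (0.46 log units; beyond the scatter), which places isobutyl apart from both other groups at this position, with the lowest number of the three compounds. No measurement at hand accounts for this difference.

Still open, going by these compounds, is how a pentyl chain ending in an amine or a carboxylic acid would read in place of 5-cyanopentyl. Also open, on these data alone, is whether an open chain other than isobutyl, such as ethyl or neopentyl, or a smaller ring such as cyclopropyl, would stand with compound 1 or with compound 3.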